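The source may hold more compounds than are shown below. What is called first, only, known or untested is meant among the compounds shown, and "the series" means these compounds.

Measured so far:
- compound 1, `Cc1ccc(C(=O)NNC(=S)Nc2csc(-c3ccccc3)c2)cc1`: 24000 nM
- compound 2, `Cc1ccc(C(=O)NNC(=S)Nc2csc(-c3ccc(C)cc3)c2)cc1`: 20000 nM
- compound 3, `COc1ccc(C(=O)NNC(=S)Nc2csc(-c3ccccc3)c2)cc1OC`: 9000 nM

All three were tested in a functional assay on B16-F10 cells (Mus musculus) for inhibition, read by colorimetric assay and MTT assay, with a stated time of 72 h; on this read-out lower numbers stand for stronger inhibition and higher numbers for weaker inhibition. Compound 2 differs from compound 1 by methyl in place of hydrogen on an aromatic carbon, and that change gave a 1.2-fold lower number from compound 1 to compound 2 (0.08 log units; within the scatter). Compound 3 has a different core from compound 1; the difference between the two cores is not broken down here. Among the three, compound 3 gives the lowest number, and its steps to both others lie beyond the scatter.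

Compound 4, `COc1ccc(C(=O)NNC(=S)Nc2csc(-c3ccc(C)cc3)c2)cc1OC`, is not yet measured. It differs from compound 3 by methyl in place of hydrogen on an aromatic carbon, the same change as between compound 1 and compound 2. Because that earlier change gave a 1.2-fold lower number from compound 1 to compound 2 (0.08 log units; within the scatter), a step of similar size is expected here, namely a 1.2-fold lower number from compound 3 to compound 4 (0.08 log units; within the scatter). Compound 4 is therefore estimated at 7500 nM in this assay, with the true value expected between 4000 nM and 16000 nM.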

Compound 4, half-maximal inhibitory concentration: 7000 nM
Compound 4: middle estimate off by 1.1-fold (0.03 log units), on the high side, and the stated range covers the measured number.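

In this assay, going from phenyl to 4-methylphenyl gave a 1.3-fold lower number from compound 3 to compound 4 (0.11 log units; within the scatter) on the core of compound 3. The same change gave steps of matching size on the two cores: the same change on two cores in this assay, a 1.2-fold lower number (0.08 log units; within the scatter) from compound 1 to compound 2 and a 1.3-fold lower number (0.11 log units; within the scatter) from compound 3 to compound 4, 1.1-fold (0.03 log units) apart, within the scatter of two such steps. This shows that on these two cores the methyl moves the number by no more than the usual scatter, but with steps this small it does not show that a large effect would carry across, and two cores say nothing about any other core in the series.

The compounds shown leave open what a different group at the same place would do, such as a chlorine atom, an amine or a longer chain like propyl. As far as these compounds go, whether any of these would carry from one core to the other also remains open.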